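This account rests on a few compounds, and the source may have more. Where it says the series, first, only, none or still open, it means among the compounds named here.

Among the measured compounds shown here, compound 2 `C#CCSc1nc(Sc2nccs2)c(C#N)c(-c2ccc(Br)cc2)n1` gives 11600 nM in a functional assay on MCF7 cells (Homo sapiens) for antiproliferative activity, read by MTT assay, with a stated time of 72 h (a lower number here means a stronger inhibitor, a higher number a weaker inhibitor), the only number available so far. Compound 1 `C#CCSc1nc(Sc2ccccn2)c(C#N)c(-c2cc(OC)c(OC)c(OC)c2)n1` reads > 10000 nM in this assay, and that reading is a limit of the assay, not a number. The next entry is compound 3 `C#CCSc1nc(Sc2nccs2)c(C#N)c(-c2ccc[nH]2)n1`, which keeps the shared core of compound 2 but carries 1H-pyrrol-2-yl in place of 4-bromophenyl on an aromatic carbon. For the measured compounds named here, no pair of measured compounds differs in one place, so no measured step is available to size this change. The expectation therefore rests only on compound 2 at 11600 nM. In this assay, no shift beyond the usual scatter is expected, and the estimated move is a 1.2-fold higher number from compound 2 to compound 3 (0.08 log units; within the scatter). The estimate for compound 3 is 14000 nM, with an expected range of 5000 nM to 40000 nM.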

Compound 3, half-maximal inhibitory concentration: > 20000 nM
Compound 3: a limit, no number; the forecaster's own chance of this, stated with the estimate: 35%; middle value at least 1.4-fold (0.15 log units) away from the limit.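

In this assay, among the compounds shown here, 1H-pyrrol-2-yl in place of 4-bromophenyl, on the aromatic carbon ortho to a cyano group, gives the first single-place step (an at least 1.7-fold higher number from compound 2 to compound 3 (0.23 log units; that floor lies within the scatter)). On these data alone, compound 3 reads as a limit of the assay and not a number, so the true size of this step stays open: the limit of > 20000 nM in this assay, at which 1 of the 3 values shown sits. Even so, this reading gives no sign that the five-membered ring with its hydrogen-bond donor makes a stronger inhibitor than 4-bromophenyl does at this position.

The compounds shown do not separate the part played by the bromine from that of the six-membered ring, and a plain phenyl or a 4-aminophenyl at this position would address that. Compound 1 differs from compound 2 in more than one place, so the thiazolylsulfanyl group remains without a step of its own.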